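Amino in place of nitro

The source may report more compounds than this note shows. Statements on the series, on what has been measured and on what is new or still open speak of the compounds shown alone.

Going by the values given here, compound 1 `COC(=O)C1(c2ccc([N+](=O)[O-])cc2)CC1CN1CCN(c2ccccn2)CC1` is the tighter binder of the two compounds measured so far in an assay for displacement of a labelled ligand from Sigma non-opioid intracellular receptor 1 (Cavia porcellus) (on this read-out lower numbers stand for stronger inhibition and higher numbers for weaker inhibition), where compound 1 gives 769 nM. Compound 2 `COC(=O)C1(c2ccccc2)CC1CN1CCN(c2ncccn2)CC1`, which differs at several places, gives 3090 nM in this assay, a higher number that lies beyond the scatter. Compound 3 `COC(=O)C1(c2ccc(N)cc2)CC1CN1CCN(c2ccccn2)CC1` keeps the core of compound 1 and differs only by amino in place of nitro on an aromatic carbon. Among the compounds with values here, with no measured step of this kind available, the shift from compound 1 to compound 3 is expected to be small, a 1.6-fold higher number from compound 1 to compound 3 (0.19 log units; within the scatter), at most a modest weakening that may not exceed the scatter. Compound 3 is therefore estimated at 1200 nM, within a range of 400 nM to 4000 nM.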

Compound 3, inhibition constant: > 10000 nM
Compound 3: a limit, no number; the forecaster's own chance of this, stated with the estimate: 5%; middle value at least 8.3-fold (0.92 log units) away from the limit.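

In this assay compound 3 gives > 10000 nM as a limit of the assay, not a number. Going by these compounds alone, the change from 4-nitrophenyl to 4-aminophenyl brings an at least 13-fold higher number from compound 1 to compound 3 (1.11 log units; beyond the scatter) and so shows that binding depends strongly on the group at this place on the aromatic ring, which the earlier compounds could not show. The size of this step is only a lower bound: the limit of > 10000 nM in this assay, at which 1 of the 3 values shown sits.

From the compounds shown here alone, how far compound 3 truly lies from compound 1 remains open. Also open, going by these compounds, is whether a methoxy, a chloro or an acetamide at this place would keep the binding of compound 1.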